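The compounds below may be only part of what the source reports. "The series", "measured", "known", "first", "only" and "open" are said of these compounds alone.

Of the compounds shown here, three have been measured in a functional assay on SK-OV-3 cells (Homo sapiens) for inhibition, read by CCK-8 assay, with a stated time of 70 h; on this read-out higher numbers stand for weaker inhibition and lower numbers for stronger inhibition. Compound 1, `c1ccc(COc2ccc(COc3ccc(OCCOCCNC4CCCCC4)cc3)cc2)cc1`, gives 8080 nM; compound 2, `O=[N+]([O-])c1ccccc1COc1ccc(OCCOCCNC2CCCCC2)cc1`, gives 2880 nM; and compound 3, `Nc1ccc(COc2ccc(OCCOCCNC3CCCC3)cc2)cc1`, gives 31700 nM. On these numbers compound 3 stands highest of the three: its nearest neighbour is compound 1, whose number is lower by an amount beyond the scatter, and its furthest is compound 2, whose number is lower still. Compound 4, `O=[N+]([O-])c1cccc(COc2ccc(OCCOCCNC3CCCC3)cc2)c1`, has not yet been measured. It differs from compound 3 in one place: 3-nitrophenyl in place of 4-aminophenyl on a saturated chain carbon bound to an oxygen on an aromatic ring. Within the data shown here, no single-point step between measured compounds is available to calibrate this change, since compound 2 and compound 3 differ from one another in more than one place. Among the measured compounds shown here, still, the only measured compound carrying a nitrophenyl group, compound 2, shows the lowest number of the set with 2880 nM, and on that basis a step from compound 3 to compound 4 toward a lower number, beyond the scatter, is expected, a 4.0-fold lower number from compound 3 to compound 4 (0.60 log units; beyond the scatter). For compound 4 the estimate in this assay is 8000 nM, within a range from 2500 nM to 25000 nM.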

Compound 4, half-maximal inhibitory concentration: 15400 nM
Beside the measured number, compound 4's estimate is 1.9-fold (0.28 log units) below it, and the stated range covers the measured number.
By their numbers in this assay, from the lowest: compound 2; then compounds 1 and 4 (each within the scatter of the next); then compound 3.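

In this assay, among these compounds, the change from 4-aminophenyl to 3-nitrophenyl, on a saturated chain carbon bound to an oxygen on an aromatic ring, gives a 2.1-fold lower number from compound 3 to compound 4 (0.31 log units; beyond the scatter) as the only single-place step in the set, and a modest one. Among the compounds shown here, it shows that this position accepts a group with more heavy atoms, no hydrogen-bond donor and more hydrogen-bond acceptors without the number rising, which the earlier compounds, differing in more than one place, could not show. Nothing at hand gives a reason for the step.

The step changes the group and its place on the ring together, leaving open how much belongs to each. Also open, as far as these compounds go, is how a plain phenyl, a methoxy group or a carboxylic acid on that ring would read on the core of compound 3.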